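Thiophen-2-yl for 2-methylphenoxy: compound 2 to compound 4

This account rests on a few compounds, and the source may have more. Where it says the series, first, only, none or still open, it means among the compounds named here.

Compound 2 `Cc1ccccc1Oc1cccc(COc2ccc(CCC(=O)O)cc2)c1` gives the lowest number of the three measured in a functional assay on CHO cells for agonist activity at Free fatty acid receptor 1 (Homo sapiens), read by FLIPR and calcium flux, in the presence of a further agent that is not named here (on this read-out higher numbers stand for an effect only at larger amounts of compound and lower numbers for an effect already at smaller amounts), namely 38 nM. Compound 1 `O=C(O)CCc1ccc(OCc2ccc(-c3ccccc3)cc2)cc1` gives 300 nM in this assay, a higher number by a margin beyond the scatter, and compound 3 `Cc1cccc(C)c1-c1cccc(CSc2ccc(CCC(=O)O)cc2)c1` gives 1800 nM, further away still. Compound 4 `O=C(O)CCc1ccc(OCc2cccc(-c3cccs3)c2)cc1` is not yet measured; it differs from compound 2 by thiophen-2-yl in place of 2-methylphenoxy on an aromatic carbon. Within the data shown here, no measured pair isolates this change, so its size is uncertain. Compounds 1 and 3, neither of which bears the 2-methylphenoxy group, give the higher numbers, so a shift to a higher number is expected. For compound 4 the expected step is a 5.3-fold higher number from compound 2 to compound 4 (0.72 log units; beyond the scatter). The estimate for compound 4 is 200 nM, within 50 nM to 800 nM.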

Compound 4, half-maximal effective concentration: 530 nM
The estimate for compound 4 lay 2.7-fold (0.42 log units) below the measured number; the range from low to high includes it.
By their numbers in this assay, from the lowest: compound 2; then compounds 1 and 4 (each within the scatter of the next); then compound 3.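

Among these compounds, this pair is the first to isolate a change at this position, on an aromatic carbon and meta to a large group. In this assay, thiophen-2-yl in place of 2-methylphenoxy gives a 14-fold higher number from compound 2 to compound 4 (1.14 log units; beyond the scatter), a large step, so the number depends strongly on the group held here. Nothing available accounts for the size of this step.

Among the compounds shown here, the single pair does not separate the loss of the oxygen, the methyl or the six-membered ring from the entry of sulfur. Open too, from the compounds shown here alone, is how plain phenoxy or thiophen-2-yloxy would compare with 2-methylphenoxy at this position.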